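The source may hold more compounds than are shown below. What is called first, only, known or untested is meant among the compounds shown, and "the series" means these compounds.

Compound 1 `O=C1Nc2ccccc2/C1=N/NC(=S)Nc1ccccc1` was tested in a functional assay on KB-V1 cells (Homo sapiens) for cytotoxicity, read by MTT assay, with a stated time of 72 h (a higher number here means a weaker inhibitor, a lower number a stronger inhibitor), where compound 1 gives 1470 nM. Two other compounds share its core and differ only in the substitution of the outer aryl ring. Compound 2 `COc1ccccc1NC(=S)N/N=C1\C(=O)Nc2ccccc21` gives 2690 nM in this assay, and compound 3 `O=C1Nc2ccccc2/C1=N/NC(=S)Nc1cc(F)c(F)c(F)c1` gives 2150 nM. Compound 1 carries the smallest of the three figures, but each of the other two lies within the usual scatter of it, so the three compounds cannot be set apart on these numbers.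

Compound 4 `CC(C)(C)c1ccc(NC(=S)N/N=C2\C(=O)Nc3ccccc32)cc1` has not yet been measured. It differs from compound 1 by tert-butyl in place of hydrogen on an aromatic carbon. Among the compounds with values here, the one step that bears on this, placing a substituent on the same aryl ring, is a 1.8-fold higher number from compound 1 to compound 2 (0.26 log units; within the scatter). The values of compound 1 and compound 3 likewise show no separation. On this basis no step beyond the scatter is expected in this assay, in either direction; the step expected from compound 1 to compound 4 is a 1.1-fold higher number from compound 1 to compound 4 (0.04 log units; within the scatter). Compound 4 is therefore estimated at 1600 nM, with a range from 700 nM to 3600 nM.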

Compound 4, half-maximal inhibitory concentration: 710 nM
For compound 4 the middle estimate is 2.3-fold (0.35 log units) above the measured one, within the range that was stated.
By their numbers in this assay, from the lowest: compound 4; then compounds 1, 3 and 2 (each within the scatter of the next).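

In this assay, tert-butyl in place of hydrogen on an aromatic carbon of the outer aryl ring gives a 2.1-fold lower number from compound 1 to compound 4 (0.32 log units; beyond the scatter), a modest step but the only one printed here that lies beyond the scatter. Within the data shown here, the earlier change on this ring, methoxy in place of hydrogen, gave a 1.8-fold higher number from compound 1 to compound 2 (0.26 log units; within the scatter), so compound 4 is the first to show that a substituent on this ring can shift the number, and that the shift can be downward, while compound 2 shows that not every substituent does so. No evidence is at hand that accounts for this step.

The compounds shown leave open whether a smaller alkyl group such as methyl or ethyl at the same carbon would give a similar step. They also leave open how an amine or a carboxylic acid there would compare with tert-butyl.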